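Positional shift of the acid on the biaryl of compound 1

The source may report more compounds than this note shows. Statements on the series, on what has been measured and on what is new or still open speak of the compounds shown alone.

Compound 1 `COc1ccc(C(=O)O)cc1-c1cccc(COc2ccc3c(c2)CN(C2CCCC2)C3=O)c1`: 80 nM
Compound 2 `Cc1ccc(C(=O)O)cc1-c1cccc(COc2ccc3c(=O)n(C4CCCC4)sc3c2)c1`: 740 nM

Compound 1 gives the lower of the two numbers in an assay on HEK293 cells for positive allosteric modulation of metabotropic glutamate receptor 2 (Rattus norvegicus), read by thallium flux; on this read-out lower numbers stand for an effect already at smaller amounts and higher numbers for an effect only at larger amounts of compound; compound 2 gives a value beyond the scatter above it, though the two differ in more than one place. Compound 3 `O=C(O)c1ccc(-c2cccc(COc3ccc4c(c3)CN(C3CCCC3)C4=O)c2)c(Cl)c1` carries 4-carboxy-2-chlorophenyl in place of 5-carboxy-2-methoxyphenyl on an aromatic carbon. For the measured compounds named here, no single-change step is available to size this move, so the expectation rests on compound 1 alone. The authors of this account estimate a loss in this assay from compound 1 to compound 3 of a 3.1-fold higher number from compound 1 to compound 3 (0.49 log units; beyond the scatter), moderate and beyond the scatter. Compound 3 is expected at 250 nM, in the range 60 nM to 1000 nM.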

Compound 3, half-maximal effective concentration: 110 nM
Estimate against measurement, compound 3: 2.3-fold (0.36 log units) above; the measured number falls inside the stated range.
By their numbers in this assay, from the lowest: compounds 1 and 3 (each within the scatter of the next); then compound 2.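

In this assay, 4-carboxy-2-chlorophenyl in place of 5-carboxy-2-methoxyphenyl gives a 1.4-fold higher number from compound 1 to compound 3 (0.14 log units; within the scatter) and so stays within the scatter. This first single-change step shows that this aromatic carbon accepts either aryl group on the core of compound 1 with no difference that can be told apart. No available evidence accounts for this result. The step moves the carboxylic acid and exchanges methoxy for chlorine together, so the contribution of each remains unresolved. On these data alone, how a nitrile on that ring, or a tetrazole replacing the carboxylic acid, would read remains open.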